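This account rests on a few compounds, and the source may have more. Where it says the series, first, only, none or still open, it means among the compounds named here.

Measured so far in a functional assay on KB cells (Homo sapiens) for cytotoxicity; on this read-out lower numbers stand for an effect already at smaller amounts and higher numbers for an effect only at larger amounts of compound:
- compound 1 `COC1=C(C)C(=O)/C(=C(O)/C=C/c2ccc(Br)cc2)C(=O)C1(C)C`: 1.9 ug/mL
- compound 2 `COC1=C(C)C(=O)/C(=C(O)/C=C/c2ccc(OC)cc2)C(=O)C1(C)C`: 2.9 ug/mL
- compound 3 `C=Cc1ccccc1/C=C/C(O)=C1/C(=O)C(C)=C(OC)C(C)(C)C1=O`: 1.1 ug/mL

On these three numbers compound 1 holds the second highest place. Its nearest neighbour is compound 2, with a 1.5-fold higher number from compound 1 to compound 2 (0.18 log units; within the scatter), so the two cannot be ordered. The furthest is compound 3, with a 1.7-fold lower number from compound 1 to compound 3 (0.24 log units; within the scatter), again within the scatter. Within the data shown here, the only step that reaches beyond the scatter is the one from compound 2 to compound 3, a 2.6-fold lower number from compound 2 to compound 3 (0.42 log units; beyond the scatter), a modest one.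

The next compound, compound 4 `COC1=C(C)C(=O)/C(=C(O)/C=C/c2ccco2)C(=O)C1(C)C`, differs from compound 1 by furan-2-yl in place of 4-bromophenyl on a double-bonded chain carbon bound to a double-bonded chain carbon.

Among the measured compounds shown here, the steps that bear on this change are those at the same place on the chain: from compound 1 to compound 3 and from compound 2 to compound 3. Both exchange one aromatic group for another and both stay small, the larger of them only modest. For the measured compounds named here, no compound with a five-membered aromatic ring at this position has been measured, so the series gives no direct reference for furan-2-yl. The expectation is therefore a number close to that of compound 1, with no step beyond the scatter in either direction, a 1.1-fold higher number from compound 1 to compound 4 (0.02 log units; within the scatter).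

Estimated for compound 4 in this assay: 2 ug/mL, within 0.9 ug/mL to 4.5 ug/mL.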

Compound 4, concentration for half-maximal effect: 8.8 ug/mL
Compound 4: the middle estimate sits 4.4-fold (0.64 log units) below what was measured; measured number above the stated range.
By their numbers in this assay, from the lowest: compounds 3, 1 and 2 (each within the scatter of the next, the first and the last beyond it); then compound 4.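

In this assay, among these compounds, the group on a double-bonded chain carbon bound to a double-bonded chain carbon proves less freely exchangeable than the earlier compounds suggested: furan-2-yl gives a 4.6-fold higher number from compound 1 to compound 4 (0.67 log units; beyond the scatter), and also a 3.0-fold higher number from compound 2 to compound 4 (0.48 log units; beyond the scatter) and an 8.0-fold higher number from compound 3 to compound 4 (0.90 log units; beyond the scatter), so compound 4 has the highest number of the four. Among the earlier groups, all with a six-membered aromatic ring of carbon only, the one step beyond the scatter was the modest one between compound 2 and compound 3, while the one five-membered aromatic ring with a hetero atom stands apart from all three. Nothing at hand explains this rise.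

Furan-2-yl is the only five-membered aromatic ring in the series, so the smaller ring and the ring oxygen cannot be told apart as the feature that goes with the higher number. Thiophen-2-yl, with sulfur in the ring, and plain phenyl would bear on that question, and whether a 4-aminophenyl group or a chain carboxylic acid at this place fits the same picture also remains open.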